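Fluoro for Methoxy on a Low-Nanomolar Antiproliferative Compound

A few compounds are considered here, and "the series" means these few. Any claim that something is new, unique, unknown or untested is made for them only; others in the source may bear on it.

Going by the values given here, in a functional assay on MCF7 cells (Homo sapiens) for antiproliferative activity, read by sulforhodamine B assay, with a stated time of 48 h (a lower number here means a stronger inhibitor, a higher number a weaker inhibitor), compound 1 (`COc1ccc(C2=NN(c3ccccc3)C(c3ccc(OC)cc3)C2O)cc1`) gives 19 nM and holds the lower of the two numbers known so far. Compound 2 (`COc1ccc(C2=CC(c3ccc(Br)cc3)NC(=S)N2)cc1`) gives 126 nM in this assay and so sits higher, by a gap beyond the usual scatter of repeated measurements.

Compound 3 (`COc1ccc(C2=NN(c3ccccc3)C(c3ccc(F)cc3)C2O)cc1`) keeps the core of compound 1 but carries fluoro in place of methoxy on an aromatic carbon, para to a large group (fluoro in place of methoxy on an aromatic carbon), so a 4-methoxyphenyl becomes a 4-fluorophenyl. Among the compounds with values here, no measured pair shows this swap, so the expectation rests on thin evidence. Compound 1 at 19 nM already sits low, which makes a rise the likelier direction, though this is a judgement and not a measured trend. The expected change is a 3.2-fold higher number from compound 1 to compound 3 (0.50 log units; beyond the scatter) in the direction of weaker inhibition, a modest loss that may only just clear the scatter. The estimate for compound 3 is 60 nM with an expected range of 15 nM to 250 nM in this assay once it is measured.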

Compound 3, half-maximal inhibitory concentration: 16 nM
Beside the measured number, compound 3's estimate is 3.8-fold (0.57 log units) above it; the measured number falls inside the stated range.
By their numbers in this assay, from the lowest: compounds 3 and 1 (each within the scatter of the next); then compound 2.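

In this assay, the swap of a 4-methoxyphenyl for a 4-fluorophenyl now has its first measured pair (a 1.2-fold lower number from compound 1 to compound 3 (0.07 log units; within the scatter)), and on these numbers the two compounds cannot be told apart. At this place, on an aromatic carbon para to a large group, one heavy atom stands in for two and the hydrogen-bond acceptor counted on methoxy is gone, yet compound 3 stays in the same low range as compound 1, while the other 4-methoxyphenyl of the shared core remains in both. Nothing measured here on the two groups or the two compounds accounts for this result, which stands as a single observation.

From the compounds shown here alone, one pair says little about how much room this position offers: whether an amine, a carboxylic acid, chloro or a longer chain such as butoxy would also stay within the scatter of compound 1 remains open. Also open, going by these compounds, is whether the same swap on the other 4-methoxyphenyl of compound 1 would give a similar result, and whether this pair's outcome holds in any other cell line.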